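Methoxy for chloro on the anilino ring of compound 2

The compounds below may be only part of what the source reports. "The series", "measured", "known", "first", "only" and "open" are said of these compounds alone.

Of the compounds shown here, two have numbers so far. In a functional assay on PC-3 cells (Homo sapiens) for antiproliferative activity, read by MTT assay, with a stated time of 48 h (on this read-out higher numbers stand for weaker inhibition and lower numbers for stronger inhibition), compound 1 `COc1ccc(N/C=C\C(=O)c2cn(-c3ccccc3)nc2-c2ccc(F)cc2)cc1` gives 4600 nM. Compound 2 `COc1ccc(-c2nn(-c3ccccc3)cc2C(=O)/C=C\Nc2ccc(Cl)cc2)cc1` gives 3890 nM in this assay, the lowest of the two numbers; compound 1 sits nearest with a higher number, though the gap between the two lies within the scatter, so no order between them is claimed.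

Compound 3 `COc1ccc(N/C=C\C(=O)c2cn(-c3ccccc3)nc2-c2ccc(OC)cc2)cc1` is not yet measured. It differs from compound 2 in one place: methoxy in place of chloro on an aromatic carbon, para to a large group. For the measured compounds named here, no measured pair isolates this change, so nothing in the data sets its size. The expectation is a step from compound 2 to compound 3 of a 1.3-fold higher number from compound 2 to compound 3 (0.11 log units; within the scatter), not beyond the scatter in either direction. For compound 3 the estimate in this assay is 5000 nM, with a range from 2500 nM to 10000 nM.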

Compound 3, half-maximal inhibitory concentration: 13400 nM
Compound 3: middle estimate off by 2.7-fold (0.43 log units), on the low side; measured number above the stated range.
By their numbers in this assay, from the lowest: compounds 2 and 1 (each within the scatter of the next); then compound 3.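

In this assay the series now has its first comparisons of compounds differing in one place, and the change from (4-chlorophenyl)amino to (4-methoxyphenyl)amino gives a 3.4-fold higher number from compound 2 to compound 3 (0.54 log units; beyond the scatter). Methoxy in place of fluoro on an aromatic carbon, at a different place in the structure, gives a 2.9-fold higher number from compound 1 to compound 3 (0.46 log units; beyond the scatter), so in these two pairs the compound with a second methoxy has the higher number whichever halogen it replaces. Nothing measured here accounts for either step.

The compounds shown leave open whether these steps belong to methoxy itself or to the loss of the halogen; hydrogen or methyl on the same aromatic carbons would separate the two. Whether chloro and fluoro are interchangeable at either place also remains unresolved.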